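This account rests on a few compounds, and the source may have more. Where it says the series, first, only, none or still open, it means among the compounds named here.

In an ADME assay on HEK293 cells (Homo sapiens) for cytotoxicity, read by fluorescence and resazurin assay, with a stated time of 24 h (on this read-out higher numbers stand for lower toxicity in this test and lower numbers for higher toxicity in this test), compound 1 `O=S1(=O)C=C(Sc2nnc(-c3ccccc3Cl)o2)c2ccccc21` gives 4000 nM while compound 2 `Cc1ccc(-c2nnc(SC3=CS(=O)(=O)c4ccccc43)o2)cc1` gives 3000 nM and compound 3 `O=S1(=O)C=C(Sc2nnc(-c3cccc(Cl)c3)o2)c2ccccc21` gives 6000 nM as its result. Compound 3 thus lies within the scatter of both other compounds, so the three cannot be ranked. Compound 4 `O=S1(=O)C=C(Sc2nnc(-c3ccc(Cl)cc3)o2)c2ccccc21` carries 4-chlorophenyl in place of 3-chlorophenyl on an aromatic carbon, and nothing else differs: 4-chlorophenyl in place of 3-chlorophenyl on an aromatic carbon is the whole change. The closest measured swaps of this group are a 1.5-fold higher number from compound 1 to compound 3 (0.18 log units; within the scatter) and a 2.0-fold higher number from compound 2 to compound 3 (0.30 log units; within the scatter) and both stay within the scatter, as does a 1.3-fold lower number from compound 1 to compound 2 (0.12 log units; within the scatter) for the remaining pair. The estimated step is therefore a 1.3-fold lower number from compound 3 to compound 4 (0.12 log units; within the scatter) with no shift expected beyond the scatter. Compound 4 is expected at 4500 nM with an estimated range from 2200 nM to 9000 nM by this reasoning.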

Compound 4, half-maximal cytotoxic concentration: 3000 nM
Beside the measured number, compound 4's estimate is 1.5-fold (0.18 log units) above it; measured number inside the range.
By their numbers in this assay, from the lowest: compounds 2, 4, 1 and 3 (each within the scatter of the next).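

In this assay, the chlorine's place on the phenyl ring makes no step beyond the scatter, whether 4-chlorophenyl replaces 3-chlorophenyl (a 2.0-fold lower number from compound 3 to compound 4 (0.30 log units; within the scatter)) or 2-chlorophenyl (a 1.3-fold lower number from compound 1 to compound 4 (0.12 log units; within the scatter)). Exchanging methyl for chloro on the same ring is equally unresolved (no change at the digits printed from compound 2 to compound 4 (within the scatter)), so all four compounds now form one group within the scatter of its neighbours. No supporting measurement explains this. Still open, going by these compounds, is whether the read-out stays within the scatter when the phenyl ring carries an amine or a carboxylic acid.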